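A few compounds are considered here, and "the series" means these few. Any claim that something is new, unique, unknown or untested is made for them only; others in the source may bear on it.

Measured in a functional assay on MCF7 cells (Homo sapiens) for cytotoxicity, read by MTT assay, with a stated time of 72 h; a lower number here means a stronger inhibitor, a higher number a weaker inhibitor:
- Compound 1 `COc1ccc(/C=C2\CCC/C(=C\c3cccc(Br)c3)C2=O)cc1OC`: 5300 nM
- Compound 2 `COc1ccc(/C=C2\CCC/C(=C\c3ccc(Br)cc3)C2=O)cc1OC`: 6900 nM
- Compound 3 `COc1ccc(/C=C2\CCC/C(=C\c3cccc(O)c3)C2=O)cc1OC`: 2900 nM

In this assay, compound 3 cannot be separated from compound 1, with a 1.8-fold lower number from compound 1 to compound 3 (0.26 log units; within the scatter). It does stand apart from compound 2, with a 2.4-fold lower number from compound 2 to compound 3 (0.38 log units; beyond the scatter).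

Compound 4 `COc1cc(/C=C2\CCC/C(=C\c3ccc(OC)c(OC)c3)C2=O)ccc1O` carries 4-hydroxy-3-methoxyphenyl in place of 3-hydroxyphenyl on a double-bonded chain carbon bound to a double-bonded ring carbon. Among the measured compounds shown here, no measured compound carries the entering group, so the evidence is indirect. The three measured steps all changed the group at this same place, and they stayed small: besides the two above, there is a 1.3-fold higher number from compound 1 to compound 2 (0.11 log units; within the scatter). For the measured compounds named here, only the step to compound 3 from compound 2 passed the scatter, and only modestly. On that basis, no change beyond the scatter is expected, and the estimated step is a 1.2-fold lower number from compound 3 to compound 4 (0.06 log units; within the scatter).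

For compound 4 the expected value is 2500 nM, with an estimated range of 1000 nM to 6500 nM.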

Compound 4, half-maximal inhibitory concentration: 7900 nM
Compound 4: middle estimate off by 3.2-fold (0.50 log units), on the low side; measured number outside the range, above it.
By their numbers in this assay, from the lowest: compounds 3, 1, 2 and 4 (each within the scatter of the next, the first and the last beyond it).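

In this assay, 4-hydroxy-3-methoxyphenyl in place of 3-hydroxyphenyl gives a 2.7-fold higher number from compound 3 to compound 4 (0.44 log units; beyond the scatter), so a hydroxy group on the phenyl at this place does not by itself keep the number low, and changes here can also raise it beyond the scatter. The new group cannot be separated from either bromophenyl group, with a 1.1-fold higher number from compound 2 to compound 4 (0.06 log units; within the scatter) and a 1.5-fold higher number from compound 1 to compound 4 (0.17 log units; within the scatter), so all the changes at this place remain modest or within the scatter. No evidence is available to explain this result.

The compounds shown do not tell whether the added methoxy group or the different location of the hydroxy group accounts for the step, as both change together. As far as these compounds go, how an amine or a carboxylic acid on the phenyl group at this place would behave also stays open.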